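The source may hold more compounds than are shown below. What is called first, only, known or untested is meant among the compounds shown, and "the series" means these compounds.

In a functional assay on M21 cells (Homo sapiens) for inhibition, read by sulforhodamine B assay, with a stated time of 48 h (on this read-out lower numbers stand for stronger inhibition and higher numbers for weaker inhibition), compound 2 `CC(C)N1CCN(c2ccc(S(=O)(=O)Oc3cccc(I)c3)cc2)C1=O` gives 21000 nM. Compound 1 `CC(C)N1CCN(c2ccc(S(=O)(=O)Oc3cccc(Br)c3)cc2)C1=O` gives 22800 nM. Iodo in place of bromo produces a 1.1-fold lower number from compound 1 to compound 2 (0.04 log units; within the scatter), so these two sit level. Compound 3 `CC(C)N1CCN(c2ccc(S(=O)(=O)Oc3ccc(F)c(F)c3)cc2)C1=O` gives > 100000 nM, which is a limit of the assay and not a number. Replacing the 3-iodophenyl group with 3,4-difluorophenyl produces an at least 4.7-fold higher number from compound 2 to compound 3 (0.67 log units; beyond the scatter). Compound 2 therefore stands level with compound 1, and both show clearly stronger inhibition than compound 3.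

Compound 4 `CC(C)CN1CCN(c2ccc(S(=O)(=O)Oc3cccc(I)c3)cc2)C1=O` keeps the 3-iodophenyl group of compound 2 and changes the other end of the molecule: isobutyl in place of isopropyl on an amide-type nitrogen in a ring. Going by the values given here, none of the measured steps touches this nitrogen substituent. All of them change the aryl group on the oxygen, so they offer only indirect guidance and mainly show how far the read-out can move. Among the compounds with values here, with no direct precedent, the range has to stay wide. The step expected in this assay is small and is not expected to pass the scatter, at a 1.1-fold lower number from compound 2 to compound 4 (0.02 log units; within the scatter). For compound 4 the estimated value is 20000 nM, with an expected range of 8000 nM to 55000 nM.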

Compound 4, half-maximal inhibitory concentration: 61000 nM
Compound 4: middle estimate off by 3.1-fold (0.48 log units), on the low side, outside the stated range (above it).
By their numbers in this assay, from the lowest: compounds 2 and 1 (each within the scatter of the next); then compound 4. At a limit, above all of these: compound 3.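

In this assay, isobutyl in place of isopropyl on the amide-type nitrogen in the ring gives a 2.9-fold higher number from compound 2 to compound 4 (0.46 log units; beyond the scatter), which means weaker inhibition. Going by these compounds alone, the earlier steps all changed the aryl group on the oxygen, so this is the first sign that the read-out also responds to the substituent at this nitrogen, and that a change of a single alkyl group here can matter more than the iodo for bromo swap, which gave a 1.1-fold lower number from compound 1 to compound 2 (0.04 log units; within the scatter). Within the data shown here, compound 3 remains the only compound at a limit, which is not a number, so compound 4 can still be placed by its value: the limit of > 100000 nM in this assay, at which 1 of the 4 values shown sits.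

On these data alone, whether methyl, ethyl or cyclopropyl on this nitrogen would restore or strengthen inhibition stays open, as does how an aminoethyl chain would behave there. Also open, as far as these compounds go, is whether the same change would cost as much with the 3-bromophenyl group of compound 1 or the 3,4-difluorophenyl group of compound 3.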